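The compounds below may be only part of what the source reports. "The series", "measured", "known", "first", "only" and "open" are said of these compounds alone.

Of the compounds shown here, three have been measured in an assay on CHO cells for displacement of a labelled ligand from adenosine receptor A3 (Homo sapiens), with a stated time of 60 min; on this read-out lower numbers stand for stronger inhibition and higher numbers for weaker inhibition. Compound 1 `CCCCC#Cc1nc2c(N)ncnc2n1[C@@H]1OC[C@@H](O)[C@H]1O` gives 31.7 nM, compound 2 `CCCCC#Cc1nc(NCc2cccc(I)c2)c2ncn([C@@H]3OC[C@@H](O)[C@H]3O)c2n1` gives 220 nM, and compound 3 `CCCC/C=C/c1nc(N)c2ncn([C@@H]3OC[C@@H](O)[C@H]3O)c2n1` gives 218 nM. Compound 2 has the highest number of the three; its number and that of compound 3 lie within the scatter of each other, while compound 1 sits well below it, a gap beyond the scatter. The next compound, compound 4 `CCCCC#Cc1nc(NCc2cccc(Br)c2)c2ncn([C@@H]3OC[C@@H](O)[C@H]3O)c2n1`, differs from compound 2 only in one place: bromo in place of iodo on an aromatic carbon. Within the data shown here, no measured pair shows this exact change. Since one halogen replaces another on the same aromatic carbon, the expected step from compound 2 to compound 4 is small, a 1.4-fold higher number from compound 2 to compound 4 (0.13 log units; within the scatter), with no direction beyond the scatter. Compound 4 is expected to give about 300 nM, with a range from 120 nM to 750 nM.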

Compound 4, inhibition constant: 67 nM
Compound 4: the middle estimate sits 4.5-fold (0.65 log units) above what was measured, outside the stated range (below it).
By their numbers in this assay, from the lowest: compound 1; then compound 4; then compounds 3 and 2 (each within the scatter of the next).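

In this assay, the choice of halogen on this aromatic carbon matters: bromo in place of iodo gives a 3.3-fold lower number from compound 2 to compound 4 (0.52 log units; beyond the scatter). This one-atom swap, 3-iodobenzyl to 3-bromobenzyl, leaves the counts of rings, hydrogen-bond donors and acceptors unchanged, yet it still moves the number beyond the scatter. Nothing available here explains the difference between the two halogens. Still open, going by these compounds, is how chloro, fluoro or methyl would compare on this same carbon. Also open, on these data alone, is whether the step would hold with the chain of compound 3 on the core.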